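Compound 3 to compound 4: a step from a limit

A few compounds are considered here, and "the series" means these few. Any claim that something is new, unique, unknown or untested is made for them only; others in the source may bear on it.

In a functional assay on HL-60 cells (Homo sapiens) for antiproliferative activity, read by MTT assay, with a stated time of 24 h (a higher number here means a weaker inhibitor, a lower number a stronger inhibitor), compound 1 (`CCCCc1oc2ccccc2c1C(=O)c1ccc(OCC(=O)N2CCCCC2)cc1`) gives > 50000 nM as a limit. Compound 2 (`CCCCc1oc2ccccc2c1C(=O)c1ccc(OCC(=O)N2CCOCC2)cc1`) gives > 50000 nM as a limit. Compound 3 (`CCCCc1oc2ccccc2c1C(=O)c1ccc(OCC(=O)N[C@H](C)c2ccccc2)cc1`) gives > 50000 nM as a limit, so it stands without a number.

Compound 4 (`CCCCc1oc2ccccc2c1C(=O)c1ccc(OCCCC(=O)N2CCCCC2)cc1`) is not yet measured. It carries 2-((piperidin-1-yl)carbonyl)ethyl in place of (1-phenylethyl)carbamoyl on a saturated chain carbon bound to an oxygen on an aromatic ring.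

The evidence nearest to this change is a step that the two limits leave unreadable from compound 1 to compound 3 together with a step that the two limits leave unreadable from compound 2 to compound 3 and a step that the two limits leave unreadable from compound 1 to compound 2 and none of these gives a size. Within the data shown here, no measured step covers a change of the chain itself. The expectation for compound 4 therefore rests on compound 3 and on the limit of > 50000 nM in this assay, at which 3 of the 3 values shown sit, and offers no sound case for a clear gain in this assay here.

For compound 4 the expected step is a number no higher from compound 3 to compound 4 (the limit leaves the size open) with no direction that the data can support. For compound 4 the estimate is 50000 nM with an expected range of 15000 nM to 100000 nM and a reading at the limit is the likeliest result.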

Compound 4, half-maximal inhibitory concentration: 31900 nM
The estimate for compound 4 lay 1.6-fold (0.20 log units) above the measured number, within the range that was stated.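

In this assay compound 4 gives 31900 nM as the only number among the compounds shown, with 2-((piperidin-1-yl)carbonyl)ethyl on a saturated chain carbon bound to an oxygen on an aromatic ring. The change reads as an at least 1.5-fold lower number from compound 1 to compound 4 (0.19 log units; that floor lies within the scatter) against (piperidin-1-yl)carbonyl and as an at least 1.5-fold lower number from compound 2 to compound 4 (0.19 log units; that floor lies within the scatter) against (morpholin-4-yl)carbonyl, while against (1-phenylethyl)carbamoyl it reads as an at least 1.5-fold lower number from compound 3 to compound 4 (0.19 log units; that floor lies within the scatter) in the same series. This position therefore admits a change that brings the reading under the limit, but every floor lies within the scatter, so no real gain is shown: the limit of > 50000 nM in this assay, at which 3 of the 4 values shown sit.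

Going by these compounds, the steps among compound 1, compound 2 and compound 3 cannot be read, and the true size of each step to compound 4 stays open. On these data alone, how a longer chain or a carboxylic acid in place of the amide would read also remains open.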